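The compounds below may be only part of what the source reports. "The series", "measured", "known", "first", "only" and "open" are said of these compounds alone.

The measured compounds:

compound 1, `O=C(/C=C/c1c[nH]c2ccccc12)c1ccncc1`, 22%
compound 2, `O=C(/C=C/c1c[nH]c2ccc(OCc3ccccc3)cc12)c1ccncc1`, 8%
compound 3, `O=C(/C=C/c1c[nH]c2ccc(O)cc12)c1ccncc1`, 72%

In a functional assay on U-251 cells (Homo sapiens) for inhibition, read by colony formation, with stated times of 48 h and 2 weeks, tested at 10 uM (a higher number here means more inhibition at the concentration tested (going by the name of the read-out), a lower number less inhibition), compound 3 stands highest of the three. Both steps up to it are beyond the scatter: a number 50 percentage points higher from compound 1 to compound 3 (beyond the scatter), and a number 64 percentage points higher from compound 2 to compound 3 (beyond the scatter). Within the data shown here, the only change on the six-membered part of the shared core with a smaller effect is a number 14 percentage points lower from compound 1 to compound 2 (beyond the scatter).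

Compound 4, `Cc1[nH]c2ccc(O)cc2c1/C=C/C(=O)c1ccncc1`, is not yet measured. It differs from compound 3 in one place: methyl in place of hydrogen on an aromatic carbon. Among the measured compounds shown here, none of the measured steps touches this position; all three concern the oxygen substituent on the six-membered part of the core, so they give no direct guide to a methyl in place of hydrogen on the five-membered ring. With nothing to point either way, compound 4 is expected to stay near compound 3, the estimated step being a number 7 percentage points lower from compound 3 to compound 4 (within the scatter), within the scatter. Compound 4 is therefore estimated at 65%, in a range from 40% to 85%.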

Compound 4, a percentage reported as inhibition, at one concentration (the size of the read-out at that concentration, not a potency): 43%
The estimate for compound 4 lay 22 percentage points above the measured number; the range from low to high includes it.
By their numbers in this assay, from the lowest: compound 2; then compound 1; then compound 4; then compound 3.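

In this assay, the position on the five-membered aromatic ring, next to the ring nitrogen and next to the ring atom that bears a large group, proves sensitive to even a small change: methyl, with its 1 heavy atom, gives a number 29 percentage points lower from compound 3 to compound 4 (beyond the scatter) in this series. Among these compounds, the earlier steps all changed the oxygen substituent, so this is the first sign that the number for compound 3 also responds to a change elsewhere on the shared core. No measurement at hand offers an explanation for this drop.

The compounds shown leave open whether a longer chain such as ethyl, or a halogen such as chlorine, at this position would lower the number further or restore it. They also leave open whether methyl here would have the same effect on compound 1, which lacks the hydroxy group.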